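This account rests on a few compounds, and the source may have more. Where it says the series, first, only, none or still open, it means among the compounds named here.

Measured so far in an ADME assay on microsomes from liver (Homo sapiens) for metabolic stability, using NADPH, with a stated time of 10 min; on this read-out higher numbers stand for a more stable compound and lower numbers for a less stable compound:
- compound 1 `CN(C[C@H]1Cc2ncccc2CN1)[C@H]1CCCc2cccnc21`: 95%
- compound 2 `NC/C=C/CN(C[C@H]1Cc2ncccc2CN1)[C@H]1CCCc2cccnc21`: 85%

With only these two numbers, compound 2 at 85% stands within the usual scatter of compound 1. Compound 3 `NC(=O)NCCCCN(C[C@H]1Cc2ncccc2CN1)[C@H]1CCCc2cccnc21` carries 3-ureidopropyl in place of 3-aminoprop-1-en-1-yl on a saturated chain carbon bound to an amine nitrogen. Among the measured compounds shown here, only one measured step bears on this: a number 10 percentage points lower from compound 1 to compound 2 (within the scatter). For the measured compounds named here, it installed a different chain, so it is a loose guide, and no measured compound carries the new group. Nothing beyond the scatter is therefore expected in this assay. The estimate is a number 1 percentage points higher from compound 2 to compound 3 (within the scatter). For compound 3 the expected value is 86%, with an estimated range from 70% to 98%.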

Compound 3, percent of the compound remaining: 91%
Compound 3: middle estimate off by 5 percentage points, on the low side; the measured number falls inside the stated range.
By their numbers in this assay, from the lowest: compounds 2, 3 and 1 (each within the scatter of the next).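

At this position, on a saturated chain carbon bound to an amine nitrogen, a second and larger chain, 3-ureidopropyl, also leaves this assay without a change beyond the scatter, with a number 6 percentage points higher from compound 2 to compound 3 (within the scatter) and with a number 4 percentage points lower from compound 1 to compound 3 (within the scatter) on this read-out. Two quite different chains therefore sit here with the stability of the shared core still within the scatter of the compound without a chain. No measurement here explains why these numbers stay so close. Still open, as far as these compounds go, is whether a chain ending in a carboxylic acid, or a plain alkyl chain with no end group, would stay within the scatter as well.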